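A few compounds are considered here, and "the series" means these few. Any claim that something is new, unique, unknown or untested is made for them only; others in the source may bear on it.

Compound 1 `O=C1NN=C(c2ccccc2)/C1=C/Nc1cc(-c2ccco2)[nH]n1`: 63700 nM
Compound 2 `O=C1NN=C(c2ccccc2)/C1=C/Nc1cc[nH]n1`: 95300 nM

For the measured compounds named here, in a functional assay on MDA-MB-361 cells (Homo sapiens) for antiproliferative activity, read by MTT assay, with a stated time of 72 h (a lower number here means a stronger inhibitor, a higher number a weaker inhibitor), compound 2 stands at one end of the two numbers, and the only step reaching it, a 1.5-fold higher number from compound 1 to compound 2 (0.17 log units; within the scatter), lies within the scatter. Compound 3 `O=C1NN=C(c2ccccc2)/C1=C/Nc1cc(-c2ccccc2)[nH]n1` differs from compound 2 by phenyl in place of hydrogen on an aromatic carbon. Going by the values given here, the one step that bears on this, a 1.5-fold higher number from compound 1 to compound 2 (0.17 log units; within the scatter), shows that removing an aryl group at this position stayed within the scatter, so adding one is expected to give at most a small lowering, with a 1.6-fold lower number from compound 2 to compound 3 (0.20 log units; within the scatter) expected. Compound 3 is therefore estimated at 60000 nM, between 25000 nM and 150000 nM.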

Compound 3, half-maximal inhibitory concentration: 42700 nM
Compound 3: the middle estimate sits 1.4-fold (0.15 log units) above what was measured; low and high end bracket the measured number.
By their numbers in this assay, from the lowest: compounds 3, 1 and 2 (each within the scatter of the next, the first and the last beyond it).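

In this assay, for the compounds shown here, phenyl on this aromatic carbon gives the first step at this position that lies beyond the scatter (a 2.2-fold lower number from compound 2 to compound 3 (0.35 log units; beyond the scatter)), though a modest one. Phenyl and furan-2-yl are not told apart here, as the exchange between them stays within the scatter (a 1.5-fold lower number from compound 1 to compound 3 (0.17 log units; within the scatter)). Nothing available explains either step.

The compounds shown leave open whether a group other than an aromatic ring, such as an amine, a carboxylic acid or a longer chain, would give a larger step on this carbon. They also leave open whether substituents on the phenyl would change the number.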